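A ring swap on the carbonyl of compound 2

This account rests on a few compounds, and the source may have more. Where it says the series, first, only, none or still open, it means among the compounds named here.

In an ADME assay on microsomes from liver (Homo sapiens) for pharmacokinetics (a higher number here means faster removal of the compound, a lower number slower removal), compound 1 `Cn1cc(-c2ncc(C#N)c(N3C[C@@H]4C[C@H]3CN4S(=O)(=O)C3CC3)n2)cn1` gives < 16 mL/min/kg and this is a limit of the assay, not a number. Compound 2 `C[C@@H]1C[C@H]1C(=O)N1CCN(c2nc(-c3cnn(C)c3)ncc2C#N)C[C@H]1C` likewise returns only a limit, at < 16 mL/min/kg in this assay. Neither compound therefore has an exact reading, and both stand at the same place (the limit of < 16 mL/min/kg in this assay, at which 2 of the 2 values shown sit). Compound 3 `C[C@@H]1CN(c2nc(-c3cnn(C)c3)ncc2C#N)CCN1C(=O)C1CCC1` has the same atoms as compound 2, joined differently, with cyclobutyl in place of 2-methylcyclopropyl on a carbonyl carbon. For the measured compounds named here, no step between measured compounds is available to size this change. The expected step (a step that the limit leaves unreadable from compound 2 to compound 3) is therefore none beyond the scatter, in neither direction. For compound 3 the estimated clearance in this assay is 14 mL/min/kg, with an expected range from 8 mL/min/kg to 26 mL/min/kg; a further report as a limit would not be surprising.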

Compound 3, clearance: < 16 mL/min/kg
Compound 3: a limit, no number (the forecaster's own chance of this, stated with the estimate: 65%); the middle value lies beyond the limit too.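

Compound 2 and compound 3 both return only a limit in this assay, so no step can be read for cyclobutyl in place of 2-methylcyclopropyl on a carbonyl carbon: the limit of < 16 mL/min/kg in this assay, at which 3 of the 3 values shown sit.

The compounds shown leave open what the actual clearance of each one is, and whether this swap changes it at all.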